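The compounds below may be only part of what the source reports. "The series", "measured", "known", "first", "only" and "open" are said of these compounds alone.

In a functional assay on HUVEC cells (Homo sapiens) for inhibition, with a stated time of 4 days (a higher number here means a weaker inhibitor, a lower number a stronger inhibitor), three compounds share one core and differ only in the chain on an oxygen on an aromatic ring. Compound 1 `COc1ccc(C(N)=O)cc1/C=C/c1ccc(Cl)cc1` gives 87 nM and compound 2 `CCOc1ccc(C(N)=O)cc1/C=C/c1ccc(Cl)cc1` gives 190 nM in this test. Compound 3 `CCCOc1ccc(C(N)=O)cc1/C=C/c1ccc(Cl)cc1` gives 1300 nM as the highest number of the three, which makes it the weakest inhibitor here.

Compound 4 `NC(=O)c1ccc(OCCOCCO)c(/C=C/c2ccc(Cl)cc2)c1` has 2-hydroxyethoxy in place of methyl on a saturated chain carbon, two bonds along the chain from an oxygen on an aromatic ring, and 2-hydroxyethoxy in place of methyl on a saturated chain carbon, two bonds along the chain from an oxygen on an aromatic ring sums up this change.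

The closest guides are the chain extensions: a 2.2-fold higher number from compound 1 to compound 2 (0.34 log units; beyond the scatter) and a 6.8-fold higher number from compound 2 to compound 3 (0.84 log units; beyond the scatter) were both modest, and a 15-fold higher number from compound 1 to compound 3 (1.17 log units; beyond the scatter) was large overall. All three point towards a higher number as the chain grows. However, those steps added only carbon, and no measured compound carries 2-hydroxyethoxy, so this trend may not hold.

The expected change, a 1.5-fold higher number from compound 3 to compound 4 (0.19 log units; within the scatter) in this assay, leans upward but is not expected to exceed the scatter. For compound 4 the estimate is 2000 nM within an expected range of 300 nM to 10000 nM.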

Compound 4, half-maximal inhibitory concentration in the HUVEC assay: 11000 nM
Estimate against measurement, compound 4: 5.5-fold (0.74 log units) below; measured number above the stated range.
By their numbers in the HUVEC assay, from the lowest: compound 1; then compound 2; then compound 3; then compound 4.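

In the HUVEC assay, the rise in the number continues with the 2-(2-hydroxyethoxy)ethoxy chain: an 8.5-fold higher number from compound 3 to compound 4 (0.93 log units; beyond the scatter), alongside a 58-fold higher number from compound 2 to compound 4 (1.76 log units; beyond the scatter) and a 130-fold higher number from compound 1 to compound 4 (2.10 log units; beyond the scatter). Across these four compounds, each longer chain on this oxygen gives a weaker inhibitor, none goes against that order, and oxygen within the chain does not interrupt it. In a physicochemical assay for solubility, read by HPLC, in simulated intestinal fluid, with a stated time of 2 h, tested at 10 mM (on this read-out higher numbers stand for higher solubility and lower numbers for lower solubility), compound 3 gives 4 ug/mL and compound 4 gives 74 ug/mL in this test. In the physicochemical assay, the same change that costs inhibition comes with better solubility, so the two read-outs move in favourable and unfavourable directions at once: the measured solubility of compound 3, 4 ug/mL, and of compound 4, 74 ug/mL, a 19-fold higher number (1.27 log units; beyond the scatter)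

As far as these compounds go, it remains open whether the loss in inhibition follows chain length alone or the 2-hydroxyethoxy part itself. A butyl chain, which holds only carbon, or a shorter chain ending in an amine or a carboxylic acid, would help separate these two readings.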